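A few compounds are considered here, and "the series" means these few. Any claim that something is new, unique, unknown or untested is made for them only; others in the source may bear on it.

Compound 1 `COc1ccc(CSc2nnc([C@@H](C)c3ccc4cc(OC)ccc4c3)n2-c2ccc(Cl)cc2)cc1` — in a functional assay on LNCaP cells (Homo sapiens) for cytotoxicity, read by MTT assay (on this read-out lower numbers stand for stronger inhibition and higher numbers for weaker inhibition), compound 1 gives <= 400000 nM, which is a limit of the assay and not a number.
Compound 2 `COc1ccc2cc([C@H](C)c3nnc(SCc4ccc(C)cc4)n3-c3ccc(F)cc3)ccc2c1` — in this assay compound 2 gives <= 400000 nM, again a limit of the assay rather than a number.
Compound 3 `COc1ccc2cc([C@H](C)c3nnc(SCc4ccc(Cl)cc4)n3-c3ccc(Cl)cc3)ccc2c1` — in this assay compound 3 gives 110000 nM.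

Within the data shown here, compound 3 therefore holds the only number in this set; the other two results sit at the limit (the limit of <= 400000 nM in this assay, at which 2 of the 3 values shown sit). Among the measured compounds shown here, the one single-point step, chloro in place of methoxy on an aromatic carbon, runs from a limit to a number and is a step that the limit leaves unreadable from compound 1 to compound 3, so its size cannot be read.

Compound 4 `COc1ccc2cc([C@H](C)c3nnc(SCc4ccc(C)cc4)n3-c3ccc(Cl)cc3)ccc2c1` differs from compound 3 by methyl in place of chloro on an aromatic carbon. For the measured compounds named here, no measured step covers this exchange. Compound 2 carries the same 4-methylbenzyl group but with fluoro rather than chloro on the other aryl ring, and its result is a limit, so it gives no usable comparison against compound 3.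

With nothing to anchor a direction, compound 4 is expected to stay close to compound 3, an estimated step of a 1.4-fold higher number from compound 3 to compound 4 (0.13 log units; within the scatter), that is no change beyond the scatter. Compound 4 is estimated at 150000 nM in this assay, with a range from 50000 nM to 400000 nM; a limit rather than a number remains a real possibility.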

Compound 4, half-maximal inhibitory concentration: 52200 nM
Estimate against measurement, compound 4: 2.9-fold (0.46 log units) above; measured number inside the range.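

In this assay, among these compounds, the exchange of 4-chlorobenzyl for 4-methylbenzyl gives the first readable step (a 2.1-fold lower number from compound 3 to compound 4 (0.32 log units; beyond the scatter)). A number is thus obtained with either group at this position, so chloro is not required there for a readable result, and the step, though beyond the scatter, is modest. The other steps into compound 4, from compound 1 and from compound 2, cannot be read because their starting results are limits of the assay and not numbers: the limit of <= 400000 nM in this assay, at which 2 of the 4 values shown sit.

As far as these compounds go, it remains open whether the lower number belongs to methyl alone or extends to other groups at this position, such as an amine, a carboxylic acid or a longer chain like propyl. Among the compounds shown here, with only one readable step, it also remains open whether the exchange of chloro for methyl would give a similar step with fluoro in place of chloro on the 4-chlorophenyl group attached to the core.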